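This account rests on a few compounds, and the source may have more. Where it says the series, first, only, none or still open, it means among the compounds named here.

Measured compounds:
- compound 1, `CCCCCCCCCCCCCCCC(=O)Oc1ccc(OC)cc1`: "not active" (no number reported)
- compound 2, `CCCCCCCCCCCCCCCCOC(=O)c1ccc([N+](=O)[O-])cc1`: 26%

Going by the values given here, in an assay on HEK293 cells for inhibition of N-acylethanolamine-hydrolyzing acid amidase (Homo sapiens), read by scintillation counting, tested at 50 uM (on this read-out higher numbers stand for more inhibition at the one concentration tested (going by the name of the read-out) and lower numbers for less inhibition), compound 2 gives 26%, the only number available, while compound 1 has an entry without a number. The step from compound 2 to compound 3, `CCCCCCCCCCCCCCCCOC(=O)NC1CCCCC1`, is a single change: cyclohexylamino in place of 4-nitrophenyl on a carbonyl carbon. Among the compounds with values here, no step between measured compounds is available to gauge such a change, so the size and direction must be guessed. The change removes the aromatic ring and nitro group and brings in a ring bearing a hydrogen-bond donor, which makes a shift in either direction plausible; a moderate move, possibly beyond the scatter, is expected, with no strong reason to favour a rise over a fall. Compound 3 is therefore expected to give about 30% in this assay, between 5% and 60%, meaning an expected step of a number 4 percentage points higher from compound 2 to compound 3 (within the scatter).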

Compound 3, a percentage reported as inhibition, at one concentration (the size of the read-out at that concentration, not a potency): "not active" (no number reported)
For compound 3 the study gives words and no number; no gap can be computed for the estimate.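

Going by these compounds alone, compound 3 is reported in words without a number, and no step from compound 2 to compound 3 can be read. The compounds shown leave open how much inhibition changes, and in which direction, when cyclohexylamino replaces 4-nitrophenyl. No measurement shown bears on this result.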